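The source may report more compounds than this note shows. Statements on the series, on what has been measured and on what is new or still open speak of the compounds shown alone.

Working notes on the series. In an assay on isolated protein for inhibition of histone deacetylase HD1B (Zea mays) (a lower number here means a stronger inhibitor, a higher number a weaker inhibitor), compound 1 `Cn1cc(/C=C/C(=O)c2ccc(Cl)cc2)cc1/C=C/C(=O)NO` gives 29400 nM, the highest number among the three measured compounds. Compound 2 `Cn1cc(/C=C/C(=O)c2ccc3ccccc3c2)cc1/C=C/C(=O)NO` gives 1800 nM and compound 3 `C/C(=C\c1cc(/C=C/C(=O)NO)n(C)c1)C(=O)c1ccccc1` gives 570 nM in this assay, both gaps from compound 1 lying well beyond the scatter, so compound 1 is the weakest inhibitor measured so far.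

Compound 4 `Cn1cc(/C=C/C(=O)c2ccco2)cc1/C=C/C(=O)NO` is not yet measured. It differs from compound 1 by furan-2-yl in place of 4-chlorophenyl on a carbonyl carbon. Nothing in the measured set isolates this change. The step from compound 1 to compound 4 is expected to be a 1.5-fold lower number from compound 1 to compound 4 (0.17 log units; within the scatter), that is, no shift beyond the scatter is expected. Compound 4 is therefore estimated at 20000 nM, within a range of 5000 nM to 60000 nM, in this assay.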

Compound 4, half-maximal inhibitory concentration: 19700 nM
Beside the measured number, compound 4's estimate is 1.0-fold (0.01 log units) above it; measured number inside the range.
By their numbers in this assay, from the lowest: compound 3; then compound 2; then compounds 4 and 1 (each within the scatter of the next).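

In this assay, going by these compounds alone, furan-2-yl in place of 4-chlorophenyl on a carbonyl carbon gives a 1.5-fold lower number from compound 1 to compound 4 (0.17 log units; within the scatter) as the first one-place comparison at this position. At this position, then, a five-membered aromatic ring with 1 hetero atom and 1 hydrogen-bond acceptor does not separate from a six-membered aromatic ring of carbon only and a chlorine. No supporting measurement bears on this result.

On these data alone, whether an amine or a carboxylic acid on the ring at this position would separate from compound 1 remains open. So does the effect of a longer chain in place of the ring.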